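Cytotoxicity of a trifluoromethyl analogue weighed against its naphthyl parent

The compounds below may be only part of what the source reports. "The series", "measured", "known", "first", "only" and "open" are said of these compounds alone.

Compound 2 `CN(c1cc2ncc(=O)[nH]c2cc1Nc1nc(-c2cccc3ccccc23)cs1)C1CCCCC1` was tested in an ADME assay on Huh-7 cells (Homo sapiens) for cytotoxicity (on this read-out lower numbers stand for stronger inhibition and higher numbers for weaker inhibition), and gives 57400 nM, the highest of the two numbers seen. Compound 1 `CN(c1cc2ncc(=O)[nH]c2cc1NC(=O)Nc1ccccc1)C1CCCCC1` gives 5520 nM in this assay. Compound 3 `CN(c1cc2ncc(=O)[nH]c2cc1Nc1nc(C(F)(F)F)cs1)C1CCCCC1` differs from compound 2 by trifluoromethyl in place of naphthalen-1-yl on an aromatic carbon. Among the compounds with values here, no step between measured compounds covers such a change, so the direction is open; a modest move toward a lower number, possibly not beyond the scatter, is expected from compound 2 to compound 3 as a 1.6-fold lower number from compound 2 to compound 3 (0.21 log units; within the scatter). Compound 3 is estimated at 35000 nM in this assay, with a range from 9000 nM to 110000 nM.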

Compound 3, half-maximal inhibitory concentration: 37400 nM
Compound 3: middle estimate off by 1.1-fold (0.03 log units), on the low side, and the stated range covers the measured number.
By their numbers in this assay, from the lowest: compound 1; then compounds 3 and 2 (each within the scatter of the next).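

In this assay, trifluoromethyl in place of naphthalen-1-yl on the five-membered aromatic ring gives a 1.5-fold lower number from compound 2 to compound 3 (0.19 log units; within the scatter), so losing both six-membered aromatic rings at this position leaves no shift that can be told from the scatter. The step of a 6.8-fold higher number from compound 1 to compound 3 (0.83 log units; beyond the scatter) shows that the difference from the phenylcarbamoyl group on that nitrogen remains with trifluoromethyl on the ring as well. No measured evidence here bears on the reason for either step. On these data alone, whether an amine or a carboxylic acid at this position would give a number in the same range stays open.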